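The source may hold more compounds than are shown below. What is called first, only, known or untested is meant among the compounds shown, and "the series" means these compounds.

Of the compounds shown here, three built on one shared core have been tested in an ADME assay on cells (Mus musculus, strain BALB/c) for cytotoxicity, read by MTT assay, with a stated time of 24 h; a lower number here means that less compound is tolerated, a higher number that more compound is tolerated. Compound 1 `COc1cc(-c2nnc(SCc3cccc(Br)c3)o2)ccc1O` gives 382000 nM. Compound 2 `COc1cc(-c2nnc(SCc3ccccc3[N+](=O)[O-])o2)ccc1O` gives 331000 nM, and compound 3 `COc1cc(-c2nnc(SCc3ccccc3F)o2)ccc1O` gives 474000 nM. Among these three numbers compound 1 stands second highest, with compound 2 nearest and compound 3 furthest, yet all three lie within the usual scatter of one another, so no ordering among them can be read from the data.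

Compound 4 `COc1cc(-c2nnc(SCc3ccccc3Br)o2)ccc1O` has not yet been measured. It differs from compound 1 in a single place: 2-bromophenyl in place of 3-bromophenyl on a saturated chain carbon bound to a sulfur. Among the measured compounds shown here, two measured steps bear on this change. The step of a 1.2-fold higher number from compound 1 to compound 3 (0.09 log units; within the scatter) also alters the group on the saturated chain carbon bound to a sulfur, and the step of a 1.4-fold higher number from compound 2 to compound 3 (0.16 log units; within the scatter) swaps one group for another on an aromatic carbon. Neither moved the number beyond the scatter, so for this change as well no step beyond the scatter is expected in this assay, in either direction. The expected step is a 1.0-fold higher number from compound 1 to compound 4 (0.02 log units; within the scatter). Compound 4 is therefore estimated at 400000 nM, with a range from 200000 nM to 800000 nM.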

Compound 4, half-maximal cytotoxic concentration: 363000 nM
The estimate for compound 4 lay 1.1-fold (0.04 log units) above the measured number; the measured number falls inside the stated range.
By their numbers in this assay, from the lowest: compounds 2, 4, 1 and 3 (each within the scatter of the next).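

In this assay, 2-bromophenyl in place of 3-bromophenyl gives a 1.1-fold lower number from compound 1 to compound 4 (0.02 log units; within the scatter), so on the saturated chain carbon bound to a sulfur, these two bromophenyl groups cannot be told apart. On the aromatic carbon, bromo in place of fluoro gives a 1.3-fold lower number from compound 3 to compound 4 (0.12 log units; within the scatter) and bromo in place of nitro gives a 1.1-fold higher number from compound 2 to compound 4 (0.04 log units; within the scatter), so bromo, fluoro and nitro also cannot be told apart there, as each step stays within the scatter. No measurement shown here accounts for this flat result.

The phenyl groups shown carry only bromo, fluoro or nitro, so it remains open whether an amine or a carboxylic acid on that ring would move the number beyond the scatter. On these data alone, it also remains open whether a longer chain in place of the saturated chain carbon would do so.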